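This account rests on a few compounds, and the source may have more. Where it says the series, first, only, none or still open, it means among the compounds named here.

Measured compounds:
compound 1 `COc1ncc(-c2ccc3ncnc(Nc4ccc(OCCO)cc4)c3c2)cc1NS(C)(=O)=O` gives 5200 nM in a functional assay on A549 cells (Homo sapiens) for antiproliferative activity, read by sulforhodamine B assay, with a stated time of 72 h; a lower number here means a stronger inhibitor, a higher number a weaker inhibitor;
compound 2 `COc1ncc(-c2ccc3ncnc(Nc4ccc(OCCO)cc4)c3c2)cc1NS(=O)(=O)c1ccc(F)cc1F` gives 2690 nM in this assay.

Going by the values given here, compound 1 stands at the upper end of these two numbers, and its only neighbour, compound 2, lies within the scatter: a 1.9-fold lower number from compound 1 to compound 2 (0.29 log units; within the scatter). Compound 3 `COC(=O)CCn1cc(Nc2ncnc3ccc(-c4cnc(OC)c(NS(C)(=O)=O)c4)cc23)cn1` differs from compound 1 by 1-(2-(methoxycarbonyl)ethyl)-1H-pyrazol-4-yl in place of 4-(2-hydroxyethoxy)phenyl on a nitrogen on an aromatic ring. Among the compounds with values here, the one measured step, a 1.9-fold lower number from compound 1 to compound 2 (0.29 log units; within the scatter), concerns a group on a sulfonyl sulfur, a different part of the shared core, so no measured step bears on this change and no direction is indicated beyond the scatter. Compound 3 is expected to give about 5000 nM, somewhere between 1000 nM and 25000 nM. The expected step is a 1.0-fold lower number from compound 1 to compound 3 (0.02 log units; within the scatter).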

Compound 3, half-maximal inhibitory concentration: 2990 nM
Estimate against measurement, compound 3: 1.7-fold (0.22 log units) above, and the stated range covers the measured number.
By their numbers in this assay, from the lowest: compounds 2, 3 and 1 (each within the scatter of the next).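

On a nitrogen on an aromatic ring, a six-membered aromatic ring of carbon only gives way to a five-membered aromatic ring with 2 hetero atoms, and the hydrogen-bond donor of the leaving group is gone. Yet in this assay this large exchange gives only a 1.7-fold lower number from compound 1 to compound 3 (0.24 log units; within the scatter), so the two compounds cannot be told apart. Nothing available bears on why these two different groups read alike. From the compounds shown here alone, the ring and the chain change together here, so the contribution of each remains unknown. Also open, going by these compounds, is how a carboxylic acid or an amine in place of the methoxycarbonyl group would read.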